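From 4-methoxyphenyl to 3-fluorophenyl on the shared core

This account rests on a few compounds, and the source may have more. Where it says the series, first, only, none or still open, it means among the compounds named here.

In a functional assay on HT-29 cells (Homo sapiens) for inhibition, with a stated time of 72 h (on this read-out higher numbers stand for weaker inhibition and lower numbers for stronger inhibition), compound 3 (`COc1ccc(-c2cccc3c2N(S(=O)(=O)c2ccc(OC)cc2)CC3)cc1`) gives 277 nM, the highest number of the three measured, which makes it the weakest inhibitor among them. On the same core, compound 1 (`COc1ccc(S(=O)(=O)N2CCc3cccc(-c4ccco4)c32)cc1`) gives 62.5 nM and compound 2 (`COc1ccc(S(=O)(=O)N2CCc3cccc(-c4ccc(F)cc4)c32)cc1`) gives 85.5 nM. These two do not separate, with a 1.4-fold higher number from compound 1 to compound 2 (0.14 log units; within the scatter). Compound 3 does stand apart from both, with a 4.4-fold higher number from compound 1 to compound 3 (0.65 log units; beyond the scatter) and a 3.2-fold higher number from compound 2 to compound 3 (0.51 log units; beyond the scatter).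

Compound 4 (`COc1ccc(S(=O)(=O)N2CCc3cccc(-c4cccc(F)c4)c32)cc1`) has not yet been measured. It carries 3-fluorophenyl in place of 4-methoxyphenyl on an aromatic carbon. For the measured compounds named here, no measured compound carries 3-fluorophenyl, so the nearest guide is compound 2, a 4-fluorophenyl analogue, and its modest step to compound 3, a 3.2-fold higher number from compound 2 to compound 3 (0.51 log units; beyond the scatter). If that step largely reverses, a modest move to a lower number is expected, with some allowance for the different fluoro placement. The expected change is a 2.6-fold lower number from compound 3 to compound 4 (0.42 log units; beyond the scatter). The estimated value for compound 4 is 105 nM, with an expected range of 45 nM to 240 nM.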

Compound 4, half-maximal inhibitory concentration: 119 nM
For compound 4 the middle estimate is 1.1-fold (0.05 log units) below the measured one; the range from low to high includes it.
By their numbers in this assay, from the lowest: compounds 1, 2 and 4 (each within the scatter of the next); then compound 3.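

In this assay the change from 4-methoxyphenyl to 3-fluorophenyl gives a 2.3-fold lower number from compound 3 to compound 4 (0.37 log units; beyond the scatter), so the separation from compound 3 does not depend on fluoro standing as it does in 4-fluorophenyl. Moving the fluoro gives a 1.4-fold higher number from compound 2 to compound 4 (0.14 log units; within the scatter) and the change from furan-2-yl gives a 1.9-fold higher number from compound 1 to compound 4 (0.28 log units; within the scatter), which leaves compound 1, compound 2 and compound 4 unseparated, with only compound 3 standing apart. Nothing available explains why 4-methoxyphenyl stands apart from these groups at this position.

On these data alone, what remains open is whether 3-methoxyphenyl would read like 4-methoxyphenyl or like the two fluorophenyl groups. As far as these compounds go, how a phenyl carrying an amine or a carboxylic acid would read at this position also remains open.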